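Halogen swap on the pendant phenyl ring: cytotoxicity notes

The compounds below may be only part of what the source reports. "The series", "measured", "known", "first", "only" and "open" are said of these compounds alone.

The series shares one core, carried by compound 1 `COc1nc(-c2ccc(Cl)cc2)ccc1[C@@H](c1ccccc1)[C@@](O)(CCN(C)C)c1cccc2ccccc12`, compound 2 `COc1nc(-c2cccc(Cl)c2)ccc1[C@@H](c1ccccc1)[C@@](O)(CCN(C)C)c1cccc2ccccc12` and compound 3 `COc1nc(-c2cccc(F)c2)ccc1[C@@H](c1ccccc1)[C@@](O)(CCN(C)C)c1cccc2ccccc12`. Readings come from a toxicity assay on HeLa cells (Homo sapiens) for cytotoxicity; a higher number here means that more compound is tolerated, a lower number that less compound is tolerated.

Compound 1 reaches only a limit of the assay, > 64 ug/mL, not a number. This is the point (the limit of > 64 ug/mL in this assay, at which 1 of the 2 values shown sits). For compound 2 the outcome is "nd" (no result reported), so no number stands against its structure, and compound 2 cannot be placed relative to compound 1 on the readings shown.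

The change from compound 2 to compound 3 is fluoro in place of chloro on an aromatic carbon. Among the compounds with values here, only one measured value exists, and it is a limit, so no measured step is available to size this change against. Where the single known reading sits at the limit, the exchange of one halogen for another on the pendant ring is not expected to move tolerance beyond the scatter; the step from compound 2 to compound 3 in this assay is expected to be small, with no preferred direction.

Compound 3 is therefore expected to come in at 64 ug/mL, between 32 ug/mL and 128 ug/mL, most likely again reported as a limit rather than a number.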

Compound 3, half-maximal cytotoxic concentration: 62.8 ug/mL
For compound 3 the middle estimate is 1.0-fold (0.01 log units) above the measured one; the measured number falls inside the stated range.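

In this assay, within the data shown here, compound 3 gives 62.8 ug/mL, the only actual number, so a compound carrying fluoro on an aromatic carbon, meta to a large group, now has a measured tolerance rather than an estimate. Compound 1 remains a limit of the assay and not a number: the limit of > 64 ug/mL in this assay, at which 1 of the 3 values shown sits. Set against that limit, the reading gives an at least 1.0-fold lower number from compound 1 to compound 3 (0.00 log units; that floor lies within the scatter), so 3-fluorophenyl in place of 4-chlorophenyl shows no difference that can be told from the scatter, and the real size of this step stays unknown while one end of it is only a floor.

The direct exchange of 3-chlorophenyl to 3-fluorophenyl cannot be read, since compound 2 has no result reported, and the effect of the halogen cannot be separated from the effect of where it sits on the ring. Also open, going by these compounds, is how tolerance would respond to a nitrile or a trifluoromethyl group on the pendant phenyl ring, or to a longer chain in place of the dimethylaminoethyl arm on the shared core.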